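Swapping nitro for iodo on a sulfonamide

The compounds below may be only part of what the source reports. "The series", "measured", "known", "first", "only" and "open" are said of these compounds alone.

Of the compounds shown here, two have so far been tested for growth inhibition of lung cancer cells: compound 1 `CC(C)(C)c1ccc(S(=O)(=O)Nc2ccccc2)cc1` and compound 2 `Cc1ccc(NS(=O)(=O)c2ccc([N+](=O)[O-])cc2)cc1O`. In a functional assay on A549 cells (Homo sapiens) for inhibition (on this read-out lower numbers stand for stronger inhibition of growth and higher numbers for weaker inhibition of growth), compound 1 gives 16000 nM, and compound 2 gives 29000 nM, the higher of the two numbers, although the gap to compound 1 lies within the scatter of repeated measurements. Compound 3 `Cc1ccc(NS(=O)(=O)c2ccc(I)cc2)cc1O` is not yet measured; it differs from compound 2 by iodo in place of nitro on an aromatic carbon. No comparable change between measured compounds exists, so its effect cannot be read from the data. The expected step is a 1.5-fold lower number from compound 2 to compound 3 (0.16 log units; within the scatter), within the scatter in either direction. Compound 3 is expected to give 20000 nM in this assay, most likely between 6000 nM and 60000 nM.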

Compound 3, concentration for 50% growth inhibition: 15000 nM
The estimate for compound 3 lay 1.3-fold (0.12 log units) above the measured number; measured number inside the range.
By their numbers in this assay, from the lowest: compounds 3, 1 and 2 (each within the scatter of the next).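

Replacing nitro with iodo on this aromatic carbon, para to a large group, gives a 1.9-fold lower number from compound 2 to compound 3 (0.29 log units; within the scatter) in this assay. On this shared core, then, the position accepts a single iodine atom in place of nitro with no difference that stands clear of the scatter, although iodo brings none of the hydrogen-bond acceptors of nitro. Nothing available gives a reason for this result.

Going by these compounds, whether an amine or a carboxylic acid at this position would move the number beyond the scatter remains open. So does the effect of other changes elsewhere on the shared core.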